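From 3-methylphenyl to 4-methylphenyl: a level series so far

The compounds below may be only part of what the source reports. "The series", "measured", "known", "first", "only" and "open" are said of these compounds alone.

Of the compounds shown here, three have been measured in a physicochemical assay for solubility, read by HPLC, in phosphate buffer, with a stated time of 24 h, at pH 7.4, tested at 100 uM; a higher number here means a more soluble compound, a lower number a less soluble compound. Compound 1 `O=C(CCCCCNc1c(NC2CCCCC2)c(=O)c1=O)NO` gives 91000000 nM, compound 2 `Cc1ccccc1Nc1c(NCCCCCC(=O)NO)c(=O)c1=O` gives 89000000 nM, and compound 3 `Cc1cccc(Nc2c(NCCCCCC(=O)NO)c(=O)c2=O)c1` gives 79000000 nM. Compound 3 therefore stands level with the other two, with neither gap lying beyond the scatter.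

The next compound is compound 4 `Cc1ccc(Nc2c(NCCCCCC(=O)NO)c(=O)c2=O)cc1`, which has the same atoms as compound 3, joined differently: 4-methylphenyl in place of 3-methylphenyl on a nitrogen on an aromatic ring.

Among the measured compounds shown here, three measured steps bear on this change. The most direct is 3-methylphenyl in place of 2-methylphenyl, which gave a 1.1-fold lower number from compound 2 to compound 3 (0.05 log units; within the scatter). Replacing cyclohexyl with 2-methylphenyl gave a 1.0-fold lower number from compound 1 to compound 2 (0.01 log units; within the scatter), and replacing cyclohexyl with 3-methylphenyl gave a 1.2-fold lower number from compound 1 to compound 3 (0.06 log units; within the scatter). All three are small, so no step beyond the scatter is expected in this assay, and no direction can be called with any confidence. For the measured compounds named here, this expectation rests on only three compounds, none of which carries the 4-methylphenyl group.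

The expected step is a 1.1-fold higher number from compound 3 to compound 4 (0.03 log units; within the scatter). For compound 4 the estimated value is 85000000 nM, with an expected range of 60000000 nM to 100000000 nM.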

Compound 4, solubility: 8100000 nM
Compound 4: the middle estimate sits 10-fold (1.02 log units) above what was measured, and the stated range ends above it.
By their numbers in this assay, from the lowest: compound 4; then compounds 3, 2 and 1 (each within the scatter of the next).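

In this assay, the placement of the methyl group on the phenyl ring now matters: 4-methylphenyl in place of 3-methylphenyl gives a step beyond the scatter (a 9.8-fold lower number from compound 3 to compound 4 (0.99 log units; beyond the scatter)), although the computed counts for the two groups are identical. The drop is not specific to that one comparison, since 4-methylphenyl also falls away from 2-methylphenyl (an 11-fold lower number from compound 2 to compound 4 (1.04 log units; beyond the scatter)) and from cyclohexyl (an 11-fold lower number from compound 1 to compound 4 (1.05 log units; beyond the scatter)). Among the compounds shown here, the earlier level picture therefore holds only for compounds 1, 2 and 3, with compound 4 the one compound that goes against it, and the series no longer reads as indifferent to the group on this nitrogen. Nothing measured here accounts for the drop.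

Open, as far as these compounds go, is whether the low number belongs to the 4-methylphenyl group alone or extends to other groups of that pattern, such as 4-chlorophenyl or 4-methoxyphenyl. Also open, from the compounds shown here alone, is where unsubstituted phenyl would stand, level with compounds 1, 2 and 3 or down with compound 4.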